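Benzyl for methyl on selenium: a cytotoxicity estimate

A few compounds are considered here, and "the series" means these few. Any claim that something is new, unique, unknown or untested is made for them only; others in the source may bear on it.

Of the compounds shown here, three have been measured in a functional assay on MCF7 cells (Homo sapiens) for cytotoxicity, read by MTT assay, with a stated time of 72 h; a higher number here means that more compound is tolerated, a lower number that less compound is tolerated.
Compound 1 `CS/C(=N\C(=O)c1cc(-c2ccccc2)nc2ccccc12)NC(=O)c1cc(-c2ccccc2)nc2ccccc12` gives > 100000 nM, which is a limit of the assay and not a number.
Compound 2 `C[Se]/C(=N\C(=O)c1cnc2ccccc2c1)NC(=O)c1cnc2ccccc2c1` gives 60700 nM.
Compound 3 `CS/C(=N\C(=O)c1csc([N+](=O)[O-])c1)NC(=O)c1csc([N+](=O)[O-])c1` gives > 100000 nM, again a limit of the assay rather than a number.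

Compound 2 thus holds the only actual number shown in this assay; the other two values sit at the limit of > 100000 nM in this assay, at which 2 of the 3 values shown sit. Among the compounds with values here, no two measured compounds differ in only one place, so no measured step is available. Compound 4 `O=C(/N=C(/NC(=O)c1cnc2ccccc2c1)[Se]Cc1ccccc1)c1cnc2ccccc2c1` is still to be measured; it differs from compound 2 by phenyl in place of hydrogen on a saturated chain carbon bound to a selenium atom. Without a measured step to lean on, the expectation for compound 4 is a modest shift, perhaps toward less tolerance, with a 1.5-fold lower number from compound 2 to compound 4 (0.18 log units; within the scatter) as the estimated size. Compound 4 is therefore estimated at 40000 nM, with a range from 15000 nM to 100000 nM.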

Compound 4, concentration lethal to 50% of the cells: > 100000 nM
Compound 4: no number, only a limit; the forecaster's own chance of this, stated with the estimate: 25%; middle value at least 2.5-fold (0.39 log units) away from the limit.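

Within the data shown here, this is the first measured change on the carbon bound to selenium: in this assay, methyl to benzyl gives an at least 1.6-fold higher number from compound 2 to compound 4 (0.21 log units; that floor lies within the scatter). The value of compound 4 is a limit of the assay, so this step has a floor but no true size, and that floor alone does not clear the usual scatter. Adding the phenyl gives no sign of a lower number, and compound 4 joins the compounds at the limit: the limit of > 100000 nM in this assay, at which 3 of the 4 values shown sit.

From the compounds shown here alone, how the number responds to an ethyl group or a longer chain on selenium remains open. So does the effect of an amine at the end of such a chain.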